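A few compounds are considered here, and "the series" means these few. Any claim that something is new, unique, unknown or untested is made for them only; others in the source may bear on it.

Values in a functional assay on A549 cells (Homo sapiens) for inhibition, read by sulforhodamine B assay, with a stated time of 72 h; a lower number here means a stronger inhibitor, a higher number a weaker inhibitor:
- compound 1 `CC1CN(C(=O)c2c(N)sc(-c3ccc(Cl)cc3)c2-c2ccc(Cl)cc2)CCN1`: 4930 nM
- compound 2 `CN1CCN(C(=O)c2c(N)sc(-c3ccc(Cl)cc3)c2-c2ccc(Cl)cc2)CC1`: 590 nM

Compound 2 holds the lower of the two numbers. Compound 3 `Nc1sc(-c2ccc(Cl)cc2)c(-c2ccc(Cl)cc2)c1C(=O)N1CCCC1` keeps the shared core and carries pyrrolidin-1-yl in place of 4-methylpiperazin-1-yl on a carbonyl carbon. Among the compounds with values here, the one measured step at this place, an 8.4-fold lower number from compound 1 to compound 2 (0.92 log units; beyond the scatter), lies beyond the scatter, so the group on the carbonyl carbon can move the number in this assay. Within the data shown here, no measured compound carries pyrrolidin-1-yl, so that step is only a rough guide to size. A step toward a higher number is expected, estimated as a 3.1-fold higher number from compound 2 to compound 3 (0.48 log units; beyond the scatter). Compound 3 is estimated at 1800 nM, with an expected range of 500 nM to 6500 nM.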

Compound 3, half-maximal inhibitory concentration: 890 nM
The estimate for compound 3 lay 2.0-fold (0.31 log units) above the measured number; the measured number falls inside the stated range.
By their numbers in this assay, from the lowest: compounds 2 and 3 (each within the scatter of the next); then compound 1.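

In this assay, pyrrolidin-1-yl on the carbonyl carbon gives a 1.5-fold higher number from compound 2 to compound 3 (0.18 log units; within the scatter), so removing the second ring nitrogen of 4-methylpiperazin-1-yl leaves the number within the scatter. Against compound 1, the same group gives a 5.5-fold lower number from compound 1 to compound 3 (0.74 log units; beyond the scatter), so among these three compounds only the 3-methylpiperazin-1-yl amide stands apart. No measurement at hand accounts for these steps.

Still open, from the compounds shown here alone, is whether piperidin-1-yl or morpholin-4-yl on the carbonyl carbon would stay at this level. An open-chain amide such as diethylamide is equally untested by the compounds shown.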